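Working notes: chloro in place of nitro, compound 3

The source may report more compounds than this note shows. Statements on the series, on what has been measured and on what is new or still open speak of the compounds shown alone.

Measured in a functional assay on SK-N-SH cells (Homo sapiens) for cytotoxicity, read by MTT assay, with a stated time of 24 h; on this read-out higher numbers stand for weaker inhibition and lower numbers for stronger inhibition:
- compound 1 `COc1ccc(/C=C(\C#N)C(=O)N/N=C(\C)c2c(O)c3ccc(O)cc3oc2=O)cc1`: 9460 nM
- compound 2 `C/C(=N\NC(=O)/C(C#N)=C/c1ccccc1[N+](=O)[O-])c1c(O)c2ccc(O)cc2oc1=O`: 12300 nM

Among the measured compounds shown here, with only two measured compounds, the position of compound 2 at 12300 nM is easily stated: it cannot be told apart from compound 1 at 9460 nM. The step between them is a 1.3-fold higher number from compound 1 to compound 2 (0.11 log units; within the scatter).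

The next compound, compound 3 `C/C(=N\NC(=O)/C(C#N)=C/c1ccccc1Cl)c1c(O)c2ccc(O)cc2oc1=O`, keeps everything in compound 2 except one group. It has chloro in place of nitro on an aromatic carbon, ortho to a large group (chloro in place of nitro on an aromatic carbon). The same difference, cut one bond further out, reads 2-nitrophenyl to 2-chlorophenyl.

For the measured compounds named here, only one measured step bears on this change. It falls on the same aromatic ring and replaces 4-methoxyphenyl with 2-nitrophenyl, and its size, a 1.3-fold higher number from compound 1 to compound 2 (0.11 log units; within the scatter), gives no sign that this ring moves the number in this assay. Going by the values given here, one step is thin evidence, and no measured compound yet carries chloro. No shift beyond the scatter is therefore expected, and no direction can be argued.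

The expected step is a 1.2-fold lower number from compound 2 to compound 3 (0.07 log units; within the scatter). For compound 3 the estimated value is 10500 nM, with an expected range of 4800 nM to 23000 nM.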

Compound 3, half-maximal inhibitory concentration: 14000 nM
Compound 3: the middle estimate sits 1.3-fold (0.12 log units) below what was measured, within the range that was stated.
By their numbers in this assay, from the lowest: compounds 1, 2 and 3 (each within the scatter of the next).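

In this assay, chloro in place of nitro on an aromatic carbon, ortho to a large group, stays within the scatter (a 1.1-fold higher number from compound 2 to compound 3 (0.06 log units; within the scatter)). Among the compounds shown here, this is the first exchange made at this one place with the rest of the ring unchanged, and a loss of 3 heavy atoms and 2 hydrogen-bond acceptors, with 1 chlorine entering, leaves the number indistinguishable. The 2-chlorophenyl of compound 3 also stays within the scatter of the 4-methoxyphenyl of compound 1 (a 1.5-fold higher number from compound 1 to compound 3 (0.17 log units; within the scatter)), so all three ring groups now read alike, and no evidence on hand explains this flat result.

The compounds shown still leave open whether any group at this place can move the number beyond the scatter, since all three share the same core and differ only in these ring groups. An amine or a carboxylic acid on this aromatic carbon, or a longer chain in place of the chloro, would extend the comparison beyond the nitro, chloro and methoxy groups seen so far.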